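A few compounds are considered here, and "the series" means these few. Any claim that something is new, unique, unknown or untested is made for them only; others in the source may bear on it.

Measured so far in a functional assay on MOLT-4 cells (Homo sapiens) for antiproliferative activity, with a stated time of 48 h; on this read-out lower numbers stand for stronger inhibition and higher numbers for weaker inhibition:
- compound 1 `C=C(Br)C(=O)Nc1ccc(/C=C/C(=O)c2cccc(OC)c2)cc1`: 850 nM
- compound 2 `C=C(Br)C(=O)Nc1ccc(/C=C/C(=O)c2cc(OC)c(OC)c(OC)c2)cc1`: 850 nM
- compound 3 `Nc1ccc(/C=C/C(=O)c2ccc(Br)cc2)cc1`: 10000 nM

Compound 2 is level with compound 1, and these two share the lowest number of the three. Compound 3 gives 10000 nM, a number well beyond the scatter from both.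

The next compound is compound 4 `COc1cc(C(=O)/C=C/c2ccc(N)cc2)cc(OC)c1OC`, which changes compound 2 in one place: hydrogen in place of (1-bromoethenyl)carbonyl on a nitrogen on an aromatic ring. The group on the nitrogen thus goes from ((1-bromoethenyl)carbonyl)amino to amino. Within the data shown here, no measured pair isolates this change. The nearest evidence is compound 3 at 10000 nM, which also carries amino but differs from compound 2 elsewhere too, so it is a single, imperfect guide.

In this assay a large rise in the number, towards weaker inhibition and beyond the scatter, is expected. The expected step is a 9.4-fold higher number from compound 2 to compound 4 (0.97 log units; beyond the scatter). For compound 4 the estimated value is 8000 nM, with an expected range of 2000 nM to 30000 nM.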

Compound 4, half-maximal inhibitory concentration: 1500 nM
For compound 4 the middle estimate is 5.3-fold (0.73 log units) above the measured one, outside the stated range (below it).
By their numbers in this assay, from the lowest: compounds 1, 2 and 4 (each within the scatter of the next); then compound 3.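

In this assay, hydrogen in place of (1-bromoethenyl)carbonyl on the nitrogen gives a 1.8-fold higher number from compound 2 to compound 4 (0.25 log units; within the scatter), so on the core of compound 2 the two groups on this nitrogen cannot be told apart, and the (1-bromoethenyl)carbonyl group is not required for a value at this level. The plain amino group therefore does not by itself go with a high number. Nothing at hand bears on why the two compounds stand so close.

Still open, from the compounds shown here alone, is whether the same replacement on the core of compound 1 gives a step of similar size. Also open, going by these compounds, is whether an acetyl or a (1-chloroethenyl)carbonyl group on this nitrogen stays level with compound 2 and compound 4.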